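Biphenyl replaces cyanophenyl in a limit-bound pair

The source may report more compounds than this note shows. Statements on the series, on what has been measured and on what is new or still open speak of the compounds shown alone.

Compound 1 `COC(=O)[C@H](CCSC)NC(=O)c1ccc(NCc2cncn2Cc2cccc(C#N)c2)cc1-c1ccccc1` is known in a functional assay on NIH3T3 cells (Mus musculus) (a lower number here means that less compound is needed, a higher number that more compound is needed for the effect), only as a limit of the assay, and there compound 1 gives > 10 uM. Compound 2 `CSCC[C@H](NC(=O)c1ccc(NCc2cncn2Cc2cccc(C#N)c2)cc1-c1ccccc1)C(=O)O`, which carries hydrogen in place of methyl on an oxygen next to a carbonyl group, is likewise known only as a limit; in this assay compound 2 gives > 10 uM. The step between them is a step that the two limits leave unreadable from compound 1 to compound 2, since (the limit of > 10 uM in this assay, at which 2 of the 2 values shown sit). Compound 3 `COC(=O)[C@H](CCSC)NC(=O)c1ccc(NCc2cncn2Cc2ccc(-c3ccccc3)cc2)cc1-c1ccccc1` differs from compound 1 by 4-phenylphenyl in place of 3-cyanophenyl on a saturated chain carbon bound to an aromatic nitrogen. No measured step touches this change, and the single step shown cannot be read, so nothing beyond the scatter can be expected for compound 3 in either direction. For compound 3 the step expected is a number no higher from compound 1 to compound 3 (the limit leaves the size open). Compound 3 is therefore estimated at 10 uM, within 3 uM to 30 uM, and most likely reported again only as a limit.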

Compound 3, concentration for half-maximal effect: > 10 uM
Compound 3: no number, only a limit; the forecaster's own chance of this, stated with the estimate: 65%; the middle value lies on the limit itself.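

Compound 3, like compound 1, is known in this assay only as a limit, so the step between them cannot be read: the limit of > 10 uM in this assay, at which 3 of the 3 values shown sit.

The compounds shown leave open whether 4-phenylphenyl in place of 3-cyanophenyl, or hydrogen in place of methyl on the oxygen, changes the concentration needed at all.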